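Acetyl capping of the amine: cytotoxicity notes

This account rests on a few compounds, and the source may have more. Where it says the series, first, only, none or still open, it means among the compounds named here.

Compound 2 `CNc1cccc2c1nc(-c1c(F)cccc1F)n2Cc1c(F)cccc1F` carries a methylamino group on the shared core; in a toxicity assay on CCRF-CEM cells (Homo sapiens) for cytotoxicity (on this read-out higher numbers stand for lower toxicity in this test and lower numbers for higher toxicity in this test), compound 2 gives 27.2 uM. Compound 1 `CC(=O)N(C)c1cccc2c1nc(-c1c(F)cccc1F)n2Cc1c(F)cccc1F` differs by acetyl in place of hydrogen on a nitrogen on an aromatic ring. For compound 1 the read-out in this assay is only a limit, > 100 uM (the limit of > 100 uM in this assay, at which 1 of the 3 values shown sits). That change gave an at least 3.6-fold higher number from compound 2 to compound 1 (0.56 log units; beyond the scatter). Compound 3 `NCc1cccc2c1nc(-c1c(F)cccc1F)n2Cc1c(F)cccc1F` differs from compound 2 by aminomethyl in place of methylamino on an aromatic carbon; in this assay compound 3 gives 49.3 uM, and a 1.8-fold higher number from compound 2 to compound 3 (0.26 log units; within the scatter). Compound 4 `CC(=O)NCc1cccc2c1nc(-c1c(F)cccc1F)n2Cc1c(F)cccc1F` differs from compound 3 by acetyl in place of hydrogen on an amine nitrogen. This is the same kind of change as that from compound 2 to compound 1, not the same: there the place was a nitrogen on an aromatic ring whose other neighbours are aromatic carbon and saturated chain carbon, here an amine nitrogen whose other neighbour is a saturated chain carbon. For compound 4 in this assay a step of a 2.2-fold higher number from compound 3 to compound 4 (0.35 log units; beyond the scatter) is expected, because an at least 3.6-fold higher number from compound 2 to compound 1 (0.56 log units; beyond the scatter) points toward a higher number after acetylation. Compound 4 is estimated at 110 uM, between 40 uM and 300 uM.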

Compound 4, half-maximal toxic concentration: 20.8 uM
Beside the measured number, compound 4's estimate is 5.3-fold (0.72 log units) above it; the measured number lies below the stated range.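

In this assay, acetyl in place of hydrogen on an amine nitrogen gave a 2.4-fold lower number from compound 3 to compound 4 (0.37 log units; beyond the scatter), which does not match the step on the other core: the same change on two cores in this assay, an at least 3.6-fold higher number (0.56 log units; beyond the scatter) from compound 2 to compound 1 and a 2.4-fold lower number (0.37 log units; beyond the scatter) from compound 3 to compound 4, at least 8.7-fold (0.94 log units) apart, beyond the scatter of two such steps. Compound 1 stands at a limit of the assay, and the steps between the other pairs read an at least 4.8-fold lower number from compound 1 to compound 4 (0.68 log units; beyond the scatter) and a 1.3-fold lower number from compound 2 to compound 4 (0.12 log units; within the scatter). These two pairs show that the acetyl step cannot be carried unchanged from one core to the other in this series, but they do not show what sets its direction.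

Going by these compounds, it remains open whether the direction follows the place of the nitrogen or the methyl on it. A propionyl or methanesulfonyl group in place of acetyl, or an aminoethyl chain in place of aminomethyl, would extend the comparison.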